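Compound 4 against the numbers of compounds 1 to 3

This account rests on a few compounds, and the source may have more. Where it says the series, first, only, none or still open, it means among the compounds named here.

Among the compounds with values here, in an assay for inhibition of Thromboxane-A synthase (Homo sapiens), using microsomes (on this read-out higher numbers stand for weaker inhibition and lower numbers for stronger inhibition), compound 3 `Cc1ccc(OC(C)(C)C2OCC(C/C=C\CCC(=O)O)C(c3cccnc3)O2)cc1` gives 360 nM, the highest of the three numbers so far. Compound 2 `CC(C)(C)c1ccc(OC(C)(C)C2OCC(C/C=C\CCC(=O)O)C(c3cccnc3)O2)cc1` gives 280 nM, and a 1.3-fold higher number from compound 2 to compound 3 (0.11 log units; within the scatter). Compound 1 `CSc1ccc(OC(C)(C)C2OCC(C/C=C\CCC(=O)O)C(c3cccnc3)O2)c([N+](=O)[O-])c1` gives 22 nM; a 16-fold higher number from compound 1 to compound 3 (1.21 log units; beyond the scatter) and a 13-fold higher number from compound 1 to compound 2 (1.10 log units; beyond the scatter).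

Compound 4 `CC(C)(Oc1ccccc1O)C1OCC(C/C=C\CCC(=O)O)C(c2cccnc2)O1` differs from compound 3 in one place: 2-hydroxyphenyl in place of 4-methylphenyl on an oxygen on a saturated carbon. Within the data shown here, no measured step changes the ring substituents in exactly this way. Among the measured compounds shown here, two steps bear on it indirectly. The step of a 1.3-fold higher number from compound 2 to compound 3 (0.11 log units; within the scatter) shows that exchanging one carbon-only group for another on the aryl ring leaves this assay essentially unchanged, whereas a 16-fold higher number from compound 1 to compound 3 (1.21 log units; beyond the scatter) shows that a ring carrying heteroatom substituents can move the number a great deal. Since compound 4 brings a heteroatom-bearing ring, the result is expected to lie in the direction of compound 1 but not to reach it, so a moderate step is estimated, a 1.8-fold lower number from compound 3 to compound 4 (0.26 log units; within the scatter). For compound 4 the expected value in this assay is 200 nM, with a range from 50 nM to 900 nM.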

Compound 4, half-maximal inhibitory concentration: 32 nM
For compound 4 the middle estimate is 6.3-fold (0.80 log units) above the measured one, outside the stated range (below it).
By their numbers in this assay, from the lowest: compounds 1 and 4 (each within the scatter of the next); then compounds 2 and 3 (each within the scatter of the next).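

In this assay, 2-hydroxyphenyl in place of 4-methylphenyl gives an 11-fold lower number from compound 3 to compound 4 (1.05 log units; beyond the scatter), and in place of 4-(tert-butyl)phenyl it gives an 8.8-fold lower number from compound 2 to compound 4 (0.94 log units; beyond the scatter), so a step of this size at this position does not require a group as large as that of compound 1. That group has 11 heavy atoms against the 7 of 2-hydroxyphenyl, yet the two compounds cannot be told apart, with a 1.5-fold higher number from compound 1 to compound 4 (0.16 log units; within the scatter). No supporting measurement is available to explain the change on this ring.

The compounds shown leave open whether the step depends on the hydroxyl group wherever it stands, which 4-hydroxyphenyl would test, or only on 2-hydroxyphenyl. They also leave open whether 2-methoxyphenyl or 2-aminophenyl would give a number close to that of compound 4.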